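Replacing Phenyl with (Dimethylamino)methyl in Compound 3

The compounds below may be only part of what the source reports. "The series", "measured", "known", "first", "only" and "open" are said of these compounds alone.

Three measured compounds share one core and differ only in the two groups carried on a nitrogen attached to an aromatic ring. In an assay on HEK293 cells for inhibition of Steryl-sulfatase (Homo sapiens), tested at 1 uM (on this read-out lower numbers stand for a weaker effect and higher numbers for a stronger effect at the one concentration tested), compound 1 `NS(=O)(=O)Oc1ccc2c(c1)CN(C(=O)c1cccc(N(Cc3ccccc3)Cc3ccco3)c1)CC2` gives 90.5%, and compound 2 `CCN(Cc1ccc(Br)cc1)c1cccc(C(=O)N2CCc3ccc(OS(N)(=O)=O)cc3C2)c1` gives 84.5%. Compound 3 `CN(C)CCN(Cc1ccccc1)c1cccc(C(=O)N2CCc3ccc(OS(N)(=O)=O)cc3C2)c1` gives 28.6% in this assay, the lowest of the three numbers; compound 2 stands well above it and compound 1 higher still. For the measured compounds named here, the single recorded step that reaches compound 3, a number 61.9 percentage points lower from compound 1 to compound 3 (beyond the scatter), changed one thing: (dimethylamino)methyl in place of furan-2-yl on a saturated chain carbon bound to a nitrogen on an aromatic ring, and the inhibition fell sharply.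

Compound 4 `CN(C)CCN(CCN(C)C)c1cccc(C(=O)N2CCc3ccc(OS(N)(=O)=O)cc3C2)c1` applies the same kind of exchange to the remaining arm: (dimethylamino)methyl in place of phenyl on a saturated chain carbon bound to a nitrogen on an aromatic ring Cut one bond further out, the difference reads benzyl to 2-(dimethylamino)ethyl. Going by the values given here, only the step from compound 1 to compound 3 bears on this, and it was large and downward. A further fall is therefore expected, although compound 3 already stands low, so the room left is limited. Compound 4 is expected to give 10%, within 0% to 30%. That expectation amounts to an estimated step of a number 18.6 percentage points lower from compound 3 to compound 4 (beyond the scatter).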

Compound 4, a percentage reported as inhibition, at one concentration (the size of the read-out at that concentration, not a potency): 17.1%
For compound 4 the middle estimate is 7.1 percentage points below the measured one; measured number inside the range.
By their numbers in this assay, from the lowest: compound 4; then compound 3; then compounds 2 and 1 (each within the scatter of the next).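

In this assay, the second exchange also counts: the result is a number 11.5 percentage points lower from compound 3 to compound 4 (beyond the scatter), so taking phenyl off this arm lowers the number even when the other arm already ends in (dimethylamino)methyl. Compound 2 shows how much depends on the whole amino group on the aromatic carbon, with a number 67.4 percentage points lower from compound 2 to compound 4 (beyond the scatter) when bis(2-(dimethylamino)ethyl)amino replaces (4-bromobenzyl)(ethyl)amino. Neither arm of compound 4 now holds a ring, yet compound 4 still gives 17.1%, so some inhibition remains at this one concentration with the arms carrying only 2-(dimethylamino)ethyl groups.

The compounds shown offer no measurement that explains why the number falls with either exchange. They also cannot separate the loss of the phenyl ring from the arrival of the dimethylamino end, and a 2-methoxyethyl arm, a plain propyl chain or a cyclohexylmethyl arm on the same nitrogen would be needed to tell those two changes apart.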